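From a chloroethyl amide to a chloropyridyl amide

The source may hold more compounds than are shown below. What is called first, only, known or untested is meant among the compounds shown, and "the series" means these compounds.

Compound 2 `CC(Cl)C(=O)Nc1cccc(-c2nc3ccccc3s2)c1` stands lowest of the two compounds measured in a physicochemical assay for solubility, in phosphate buffer, measured as kinetic solubility, with a stated time of 18 h, at pH 7.4 (a lower number here means a less soluble compound, a higher number a more soluble compound), at 830 nM. Compound 1 `CN(C)CCC(=O)Nc1cccc(-c2nc3ccccc3s2)c1` gives 56000 nM, and the step of a 67-fold lower number from compound 1 to compound 2 (1.83 log units; beyond the scatter) is the only one measured. Compound 3 `O=C(Nc1cccc(-c2nc3ccccc3s2)c1)c1ccnc(Cl)c1` carries 2-chloropyridin-4-yl in place of 1-chloroethyl on a carbonyl carbon. That measured step exchanged a 2-(dimethylamino)ethyl group for a chloroethyl group, a change of a different kind, so it bears only loosely on the present one, in which neither group carries a net charge. Compound 3 is therefore expected to move little, a 1.7-fold lower number from compound 2 to compound 3 (0.22 log units; within the scatter), with an estimate of 500 nM and a range from 100 nM to 3000 nM.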

Compound 3, solubility: 740 nM
The estimate for compound 3 lay 1.5-fold (0.17 log units) below the measured number; the measured number falls inside the stated range.
By their numbers in this assay, from the lowest: compounds 3 and 2 (each within the scatter of the next); then compound 1.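

In this assay, a ring serves at this carbonyl carbon no differently from an open chain: 2-chloropyridin-4-yl in place of 1-chloroethyl gives a step within the scatter (a 1.1-fold lower number from compound 2 to compound 3 (0.05 log units; within the scatter)). The large gap to the 2-(dimethylamino)ethyl amide persists with this new group (a 76-fold lower number from compound 1 to compound 3 (1.88 log units; beyond the scatter)), so it now holds for two different groups without net charge. No evidence is available to explain either step. From the compounds shown here alone, whether an amine carried on the 2-chloropyridin-4-yl group would bring the number back towards that of compound 1 remains open.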